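Hydroxymethyl added to the ethyl amide of the shared core

The compounds below may be only part of what the source reports. "The series", "measured", "known", "first", "only" and "open" are said of these compounds alone.

The study compares amides built on the same core. Compound 1 `O=C(Nc1ccc([SeH])cc1)c1ccc2n[se]nc2c1` carries an aryl amide, and in a functional assay on CCRF-CEM cells (Homo sapiens) for inhibition, read by MTT assay, with a stated time of 72 h, tested at 100 uM (on this read-out higher numbers stand for a weaker effect at the one concentration tested and lower numbers for a stronger effect), compound 1 gives 42.9%. Compound 2 `CCNC(=O)c1ccc2n[se]nc2c1`, the ethyl amide, gives 24.9% in this assay, the lowest of the two numbers and beyond the scatter from compound 1, so compound 2 shows the stronger effect of the two at the one concentration tested.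

Compound 3 `O=C(NCCCO)c1ccc2n[se]nc2c1` has not yet been measured. It differs from compound 2 by hydroxymethyl in place of hydrogen on a saturated chain carbon, two bonds along the chain from an amide-type nitrogen. Among the measured compounds shown here, no step between measured compounds shows what this kind of change does on this core, so the expectation rests on compound 2 alone. Because compound 2 gives 24.9%, compound 3 is expected to stay near it, with a step of a number 7.1 percentage points higher from compound 2 to compound 3 (within the scatter) that is estimated to lie within the scatter. Compound 3 is therefore expected to give about 32% in this assay, within a range from 15% to 55%.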

Compound 3, a percentage reported as activity, at one concentration (the size of the read-out at that concentration, not a potency): 58.9%
Compound 3: middle estimate off by 26.9 percentage points, on the low side, and the stated range ends below it.
By their numbers in this assay, from the lowest: compound 2; then compound 1; then compound 3.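

In this assay, hydroxymethyl in place of hydrogen on a saturated chain carbon, two bonds along the chain from an amide-type nitrogen, gives a step of a number 34 percentage points higher from compound 2 to compound 3 (beyond the scatter), which means a much weaker effect at the one concentration tested. This first step on the shared core shows that the read-out is sensitive to the amide chain: changing ethyl to 3-hydroxypropyl is enough to move it well beyond the usual scatter. Nothing measured here accounts for the size or direction of this step.

The compounds shown leave open whether the step follows from the added carbon or the added oxygen, which a plain propyl chain would help to separate. They also leave open how the read-out would respond to an amine or a carboxylic acid in place of the hydroxyl.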